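The source may report more compounds than this note shows. Statements on the series, on what has been measured and on what is new or still open speak of the compounds shown alone.

Three compounds built on one shared core were tested in a functional assay on MCF7 cells (Homo sapiens) for inhibition; on this read-out lower numbers stand for stronger inhibition and higher numbers for weaker inhibition. Compound 1 `CCN(CC)CCNC(=O)CC(CC(=O)NC1Cc2ccccc2C1)c1ccc(Cl)cc1` gives 75000 nM. Compound 2 `O=C(CC(CC(=O)NC1Cc2ccccc2C1)c1ccc(Cl)cc1)NCCN1CCCC1` yields only a limit of the assay, > 100000 nM. Compound 3 `O=C(CC(CC(=O)NC1Cc2ccccc2C1)c1ccccc1)NCCN1CCCC1` likewise yields only a limit, > 100000 nM. Compound 2 therefore stands at the limit of > 100000 nM in this assay, at which 2 of the 3 values shown sit, and its position is known only as a limit, not as a number. The change from diethylamino to pyrrolidin-1-yl on a saturated chain carbon, two bonds along the chain from an amide-type nitrogen, brought an at least 1.3-fold higher number from compound 1 to compound 2 (0.12 log units; that floor lies within the scatter). Hydrogen in place of chloro on an aromatic carbon gave a step that the two limits leave unreadable from compound 2 to compound 3.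

Compound 4 `CCN(C(=O)CC(CC(=O)NCCN1CCCC1)c1ccc(Cl)cc1)C1Cc2ccccc2C1` differs from compound 2 by ethyl in place of hydrogen on an amide-type nitrogen. Neither measured step touches an amide-type nitrogen, so none of them bears directly on this change, and the two limits give no direction to read. Compound 4 is expected to sit near the same limit, so the estimated step is a step that the limit leaves unreadable from compound 2 to compound 4. Compound 4 is thus estimated at 150000 nM, within a range from 30000 nM to 800000 nM.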

Compound 4, half-maximal inhibitory concentration: 20400 nM
Compound 4: the middle estimate sits 7.4-fold (0.87 log units) above what was measured; measured number below the stated range.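

In this assay, ethyl in place of hydrogen on this amide-type nitrogen gave an at least 4.9-fold lower number from compound 2 to compound 4 (0.69 log units; beyond the scatter). Going by these compounds alone, this position, which no earlier step touched, is thus the first place where a change brings a step readable beyond the scatter, and the direction is towards stronger inhibition. Compound 2 is only a limit of the assay, so the true size of the step stays unknown and only its floor can be read: the limit of > 100000 nM in this assay, at which 2 of the 4 values shown sit.

Whether this shift belongs to ethyl in particular or would come with other groups on this nitrogen stays open, since neither methyl nor a longer chain such as propyl is among the compounds shown. Also open, going by these compounds, is whether ethyl would act in the same way alongside diethylamino, as in compound 1, or with hydrogen in place of chloro, as in compound 3.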